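This account rests on a few compounds, and the source may have more. Where it says the series, first, only, none or still open, it means among the compounds named here.

Measured so far:
compound 1, `COC(=O)/C=C(C)/C=C/C(F)=C(C)\C=C\c1c(C)cc(OC)c(C)c1C`: 17%
compound 2, `CCOC(=O)/C=C(C)/C(F)=C/C=C(C)/C=C/c1c(C)cc(OC)c(C)c1C`: 82%

In a functional assay on the whole organism (strain Hart Swiss) with Mus musculus as the target, with stated times of 5 days and 2 weeks, at a dose of 80 mg/kg by the intraperitoneal route (on this read-out higher numbers stand for a stronger effect at the one dose given and lower numbers for a weaker effect), compound 2 gives 82%, the higher of the two numbers. Its nearest neighbour on this read-out is compound 1, which in this assay gives 17%; the gap between these two values lies well beyond the usual scatter. Compound 1 differs from compound 2 in more than one place, so the two values show only that the series spans a wide range on this read-out.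

Compound 3, `CCOC(=O)/C=C(C)/C(F)=C\C=C(C)\C=C\c1c(C)cc(OC)c(C)c1C`, has not yet been measured. It differs from compound 2 as follows: the two compounds have the same atoms and bonds and differ only in configuration as drawn: 1 of 4 stereo elements differ; a double bond is drawn Z in compound 2 and E in compound 3. For the measured compounds named here, no step between measured compounds isolates such a change of geometry, so the expected size of the step in this assay rests on the breadth seen so far. A loss is expected, of uncertain size, possibly beyond the scatter. Compound 3 is estimated at 50% in this assay, within 15% to 85%. The expected step is a number 32 percentage points lower from compound 2 to compound 3 (beyond the scatter).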

Compound 3, a percentage reported as activity, at one dose (the size of the read-out at that dose, not a potency): 56%
Estimate against measurement, compound 3: 6 percentage points below; the range from low to high includes it.
By their numbers in this assay, from the lowest: compound 1; then compound 3; then compound 2.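

For the compounds shown here, this is the first change that can be read on its own, whereas the earlier pair differs in more than one place and shows only a range. In this assay, drawing one double bond as E rather than Z gives a number 26 percentage points lower from compound 2 to compound 3 (beyond the scatter), so configuration at this double bond alone moves the read-out at the single dose. The step can be assigned to this geometry because nothing else separates the two structures: the fact that compounds 2 and 3 differ only in the configuration as drawn

The compounds shown leave open how the other three stereo elements bear on the read-out, since no single-place step isolates any of them. They also leave open whether a step of this size would hold with a carboxylic acid or an amide in place of the ethyl ester.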